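Solubility notes: triazolyl replacement on the sulfonamide-bearing ring

The compounds below may be only part of what the source reports. "The series", "measured", "known", "first", "only" and "open" are said of these compounds alone.

Measured compounds:
compound 1 `COc1ccc(-c2cc(-c3ccc(S(=O)(=O)N(C)C)cc3)cnc2N)cn1` — 6.3 ug/mL
compound 2 `COc1ccc(-c2cc(-c3ccc(S(N)(=O)=O)cc3)cnc2N)cn1` — 12.5 ug/mL
compound 3 `COc1ccc(-c2cc(-c3ccc(NS(C)(=O)=O)cc3)cnc2N)cn1` — 25 ug/mL

All three share one core and differ only in the group on the outer benzene ring. In a physicochemical assay for solubility, read by nephelometry, in phosphate buffer, measured as kinetic solubility, at pH 6.5 (a lower number here means a less soluble compound, a higher number a more soluble compound), compound 3 has the highest of the three numbers; it is set apart from compound 1 by a 4.0-fold higher number from compound 1 to compound 3 (0.60 log units; beyond the scatter), which is beyond the scatter, whereas the step of a 2.0-fold higher number from compound 2 to compound 3 (0.30 log units; within the scatter) is within the scatter, so compound 2 and compound 3 are not distinguished by this assay. The step of a 2.0-fold higher number from compound 1 to compound 2 (0.30 log units; within the scatter) is likewise within the scatter.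

Compound 4 `COc1ccc(-c2cc(-c3ccc(-n4cncn4)cc3)cnc2N)cn1` carries the change (1H-1,2,4-triazol-1-yl in place of methanesulfonamido on an aromatic carbon). Going by the values given here, none of the measured steps touches a triazolyl group; the nearest evidence is that the one step beyond the scatter, a 4.0-fold higher number from compound 1 to compound 3 (0.60 log units; beyond the scatter), accompanied the arrival of the methanesulfonamido group that now leaves. Removing it is expected to take back some of that gain, a step estimated as a 2.5-fold lower number from compound 3 to compound 4 (0.40 log units; beyond the scatter) in this assay, in the downward direction. Compound 4 is therefore estimated at 10 ug/mL, within a range of 3 ug/mL to 35 ug/mL.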

Compound 4, solubility: 6.3 ug/mL
For compound 4 the middle estimate is 1.6-fold (0.20 log units) above the measured one, and the stated range covers the measured number.
By their numbers in this assay, from the lowest: compounds 1, 4, 2 and 3 (each within the scatter of the next, the first and the last beyond it).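

In this assay, 1H-1,2,4-triazol-1-yl on this aromatic carbon, para to a large group, does not hold the level seen with methanesulfonamido, giving a 4.0-fold lower number from compound 3 to compound 4 (0.60 log units; beyond the scatter), so compound 3 now stands beyond the scatter from two of the other three compounds. Against the two remaining groups at this place, the triazolyl group is not distinguished: sulfamoyl gives a 2.0-fold lower number from compound 2 to compound 4 (0.30 log units; within the scatter) and dimethylsulfamoyl gives no change at the digits printed from compound 1 to compound 4 (within the scatter), so a ring without a hydrogen-bond donor reads the same here as both of those groups. Nothing available on these compounds gives a reason for these steps.

As far as these compounds go, how a carboxylic acid or an aliphatic amine would read at this same place in this assay remains open. Also open, from the compounds shown here alone, is whether the standing of methanesulfonamido holds on any other core, since all four compounds share one.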